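A few compounds are considered here, and "the series" means these few. Any claim that something is new, unique, unknown or untested is made for them only; others in the source may bear on it.

For the measured compounds named here, in an ADME assay on L6 cells (Rattus norvegicus) for cytotoxicity, read by resazurin assay, with a stated time of 72 h (on this read-out lower numbers stand for stronger inhibition and higher numbers for weaker inhibition), three compounds on a shared core have numbers so far: compound 1 (`CN(C)C12CC(c3ccccc3)C(CN(C(=O)CN3CCCCC3)C1)C(c1ccccc1)C2`) gives 12100 nM, compound 2 (`CN(C)C12CC(c3ccccc3)C(CN(CCN3CCCC3)C1)C(c1ccccc1)C2`) gives 5580 nM, and compound 3 (`CN1CCN(CCCN2CC3C(c4ccccc4)CC(N(C)C)(CC3c3ccccc3)C2)CC1`) gives 200 nM, the lowest of the three. Compound 4 (`CN(C)C12CC(c3ccccc3)C(CN(CCCN3CCCC3)C1)C(c1ccccc1)C2`) departs from compound 3 in one place, with pyrrolidin-1-yl in place of 4-methylpiperazin-1-yl on a saturated chain carbon, three bonds along the chain from an amine nitrogen in a ring.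

Going by the values given here, no measured step makes this exchange alone. The nearest is a 28-fold lower number from compound 2 to compound 3 (1.45 log units; beyond the scatter), where (4-methylpiperazin-1-yl)methyl replaces pyrrolidin-1-yl, so chain and end group change together. The other two steps, a 61-fold lower number from compound 1 to compound 3 (1.78 log units; beyond the scatter) and a 2.2-fold lower number from compound 1 to compound 2 (0.34 log units; beyond the scatter), both start from the amide-bearing compound 1 and show how far this side chain can move the number. The data do not separate the share of the end group, so only part of the large step from compound 2 is expected to reverse. In this assay, the expected change is a 5.0-fold higher number from compound 3 to compound 4 (0.70 log units; beyond the scatter), clearly upward but with wide uncertainty. Compound 4 is estimated at 1000 nM, with an expected range of 250 nM to 4500 nM.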

Compound 4, half-maximal inhibitory concentration: 1550 nM
Beside the measured number, compound 4's estimate is 1.6-fold (0.19 log units) below it; low and high end bracket the measured number.
By their numbers in this assay, from the lowest: compound 3; then compound 4; then compound 2; then compound 1.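

In this assay, the exchange of 4-methylpiperazin-1-yl for pyrrolidin-1-yl now stands alone on the 3-carbon-named propyl chain, as a 7.8-fold higher number from compound 3 to compound 4 (0.89 log units; beyond the scatter), so the end group alone moves the number beyond the scatter. With pyrrolidin-1-yl kept, (pyrrolidin-1-yl)methyl in place of pyrrolidin-1-yl gives a 3.6-fold lower number from compound 2 to compound 4 (0.56 log units; beyond the scatter), so the large earlier step from the ethyl to the propyl side chain holds a share from the chain as well as from the end group. The 3-(pyrrolidin-1-yl)propyl in place of ((piperidin-1-yl)methyl)carbonyl gives a 7.8-fold lower number from compound 1 to compound 4 (0.89 log units; beyond the scatter), but no evidence here explains any of these steps.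

The compounds shown leave open how 2-(4-methylpiperazin-1-yl)ethyl would compare, since that group completes the pairing of chain and end group. They also leave open how a morpholin-4-yl end group or a longer chain would read.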